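The source may report more compounds than this note shows. Statements on the series, on what has been measured and on what is new or still open speak of the compounds shown alone.

Measured so far in a physicochemical assay for solubility; on this read-out lower numbers stand for lower solubility and higher numbers for higher solubility:
Compound 1 `CNC(=O)c1cc(C(=O)NC2CC2)cn(Cc2cccc(C)c2)c1=O` gives >= 205 ug/mL as a limit
Compound 2 `CNC(=O)c1cc(C(=O)NC2CC2)cn(Cc2cccc3[nH]ncc23)c1=O` gives 10 ug/mL as a number
Compound 3 `CNC(=O)c1cc(C(=O)NC2CC2)cn(Cc2cccc3c2CCN3)c1=O` gives >= 184 ug/mL as a limit

Compound 3 stands at >= 184 ug/mL, which is a limit and not a number. Compound 4 `CNC(=O)c1cc(C(=O)NC2CC2)cn(CC2CCOCC2)c1=O` carries oxan-4-yl in place of 2,3-dihydro-1H-indol-4-yl on a saturated chain carbon bound to an aromatic nitrogen. The change is oxan-4-yl in place of 2,3-dihydro-1H-indol-4-yl on a saturated chain carbon bound to an aromatic nitrogen.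

Two measured steps are large, an at least 20-fold lower number from compound 1 to compound 2 (1.31 log units; beyond the scatter) and an at least 18-fold higher number from compound 2 to compound 3 (1.26 log units; beyond the scatter), and both run through compound 2. The third is a step that the two limits leave unreadable from compound 1 to compound 3 and has no readable size. None of the three has oxan-4-yl on either side. Resting on that unreadable step, no step beyond the scatter is expected in this assay. The expected step is a step that the limit leaves unreadable from compound 3 to compound 4. Compound 4 is estimated at 190 ug/mL, with an expected range from 80 ug/mL to 280 ug/mL.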

Compound 4, solubility: >= 165 ug/mL
Compound 4 was reported as a limit; the forecaster's own chance of this, stated with the estimate: 65%; the middle value is on the limit's open side.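

In this assay compound 4 is reported as a limit and not a number: the limit of >= 165 ug/mL in this assay, at which 1 of the 4 values shown sits. Oxan-4-yl, a ring that is not aromatic, gives an at least 16-fold higher number from compound 2 to compound 4 (1.21 log units; beyond the scatter), so at this place on a saturated chain carbon bound to an aromatic nitrogen, the low value of compound 2 is not shared by a group without an aromatic ring. The steps from compound 1 and from compound 3 to compound 4 cannot be read. From the compounds shown here alone, how far compound 1, compound 3 and compound 4 differ from one another stays open, and so does what an amine or a carboxylic acid at this place would give.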